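A few compounds are considered here, and "the series" means these few. Any claim that something is new, unique, unknown or untested is made for them only; others in the source may bear on it.

Series notes. In an ADME assay on PANC-1 cells (Homo sapiens) for cytotoxicity, read by sulforhodamine B assay, with a stated time of 48 h, tested at 10 uM (a higher number here means more inhibition at the concentration tested (going by the name of the read-out), a lower number less inhibition), compound 1 `COc1nc2ccc(Br)cc2cc1C(c1ccccc1)n1cc(C2CC2)nn1` gives 21.8%, compound 2 `CCCCc1cn(C(c2ccccc2)c2cc3cc(Br)ccc3nc2OC)nn1` gives 5.46% and compound 3 `COc1nc2ccc(Br)cc2cc1C(c1ccccc1)n1cc(-c2cccc(F)c2)nn1` gives 15.5%. On the numbers shown compound 3 is second highest of three, but its gaps to compound 1 and to compound 2 both lie within the scatter. Compound 4 `CCCCCCCCc1cn(C(c2ccccc2)c2cc3cc(Br)ccc3nc2OC)nn1` is not yet measured; it carries octyl in place of 3-fluorophenyl on an aromatic carbon. Among the measured compounds shown here, two steps bear on this change: a number 16.3 percentage points lower from compound 1 to compound 2 (beyond the scatter) and a number 10 percentage points higher from compound 2 to compound 3 (within the scatter). Only the first is beyond the scatter, and octyl is again an open alkyl chain, so a downward step is expected because of a number 16.3 percentage points lower from compound 1 to compound 2 (beyond the scatter), roughly a number 9.5 percentage points lower from compound 3 to compound 4 (within the scatter). Compound 4 is estimated at 6% in this assay, with a range from -5% to 20%.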

Compound 4, a percentage reported as inhibition, at one concentration (the size of the read-out at that concentration, not a potency): 12.1%
For compound 4 the middle estimate is 6.1 percentage points below the measured one, within the range that was stated.
By their numbers in this assay, from the lowest: compounds 2, 4, 3 and 1 (each within the scatter of the next, the first and the last beyond it).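

In this assay, octyl at this aromatic carbon is not told apart from the other groups: the readings are a number 3.4 percentage points lower from compound 3 to compound 4 (within the scatter) and a number 6.6 percentage points higher from compound 2 to compound 4 (within the scatter) and a number 9.7 percentage points lower from compound 1 to compound 4 (within the scatter) with all three steps within the scatter. The ringless octyl thus reads like the ring-bearing 3-fluorophenyl here, and octyl in place of butyl gives no readable step either. Among the compounds shown here, compound 1 and compound 2 stay the only pair printed beyond the scatter. Open, as far as these compounds go, is whether a chain ending in an amine or a carboxylic acid at this carbon would give a step beyond the scatter. No measurement at hand accounts for these readings.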